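The source may report more compounds than this note shows. Statements on the series, on what has been measured and on what is new or still open speak of the compounds shown alone.

Measured compounds:
Compound 1 `CC(C)(C)C(=O)N1Cc2c(NC(=O)c3ccncc3)n[nH]c2C1(C)C` gives 110 nM in a functional assay on A2780 cells (Homo sapiens) for antiproliferative activity, read by fluorescence, with a stated time of 72 h; a lower number here means a stronger inhibitor, a higher number a weaker inhibitor.
Compound 2 `CCCNC(=O)Nc1n[nH]c2c1CN(C(=O)C1CCN(C)CC1)C2(C)C` gives 650 nM in this assay.
Compound 3 `CN1CCC(C(=O)N2Cc3c(NC(=O)NCc4ccccc4)n[nH]c3C2(C)C)CC1` gives 2680 nM in this assay.

Among these three, compound 1 stands at the lowest number, and so is the strongest inhibitor of the set; compound 2 lies closest to it, and compound 3 furthest. Compound 4 `CC(C)(C)C(=O)N1Cc2c(NC(=O)c3ccc(F)cc3)n[nH]c2C1(C)C` has not yet been measured. It differs from compound 1 in one place: 4-fluorophenyl in place of pyridin-4-yl on a carbonyl carbon. For the measured compounds named here, the only measured step, a 4.1-fold higher number from compound 2 to compound 3 (0.62 log units; beyond the scatter), concerns a different part of the shared core, where a group on a saturated chain carbon bound to an amide-type nitrogen was exchanged, so it does not speak directly to an exchange on a carbonyl carbon; it shows only that a single change of one ring-bearing group can move the number by a modest amount. With no closer comparison, a change of modest size in either direction, or none beyond the scatter, is the expectation in this assay, leaning toward a somewhat higher number. Compound 4 is therefore estimated at 200 nM, with a range from 60 nM to 700 nM, a step of a 1.8-fold higher number from compound 1 to compound 4 (0.26 log units; within the scatter).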

Compound 4, half-maximal inhibitory concentration: 270 nM
Beside the measured number, compound 4's estimate is 1.4-fold (0.13 log units) below it; low and high end bracket the measured number.
By their numbers in this assay, from the lowest: compound 1; then compound 4; then compound 2; then compound 3.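

For the compounds shown here, this is the first measured exchange on the carbonyl carbon, and in this assay it gives a 2.5-fold higher number from compound 1 to compound 4 (0.39 log units; beyond the scatter) when only this group changes. The position therefore responds to the exchange, yet the modest size of the step shows that activity does not depend on keeping pyridin-4-yl, as the all-carbon ring of 4-fluorophenyl still leaves compound 4 active. Nothing measured here says why the number moved.

The exchange removes the ring nitrogen and adds fluorine in one step, so a plain phenyl ring would be needed to separate the two changes. Also open, from the compounds shown here alone, is how a pyridin-3-yl ring, or an amine or carboxylic acid on this ring, would read, and whether this exchange gives a similar step with another group elsewhere on the shared core.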